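Naphthyl for tolyl on the glycosylated oxindole series

The compounds below may be only part of what the source reports. "The series", "measured", "known", "first", "only" and "open" are said of these compounds alone.

Measured compounds:
compound 1 `COc1ccc2c(c1)c(C=O)cn2Cc1cn([C@@H]2O[C@H](COC(C)=O)[C@@H](OC(C)=O)[C@H](OC(C)=O)[C@H]2OC(C)=O)nn1` — 136000 nM
compound 2 `CC(=O)OC[C@H]1O[C@@H](n2cc(CN3C(=O)/C(=C/c4ccc(C)cc4)c4ccccc43)nn2)[C@H](OC(C)=O)[C@@H](OC(C)=O)[C@@H]1OC(C)=O` — 9300 nM
compound 3 `CC(=O)OC[C@H]1O[C@@H](n2cc(CN3C(=O)/C(=C\c4ccc(C)cc4)c4ccccc43)nn2)[C@H](OC(C)=O)[C@@H](OC(C)=O)[C@@H]1OC(C)=O` — 9400 nM

In a functional assay on DU-145 cells (Homo sapiens) for cytotoxicity, read by sulforhodamine B assay, with a stated time of 48 h (a lower number here means a stronger inhibitor, a higher number a weaker inhibitor), compound 3 gives 9400 nM, the second highest of the three numbers. Compound 2 gives 9300 nM, and the step of a 1.0-fold higher number from compound 2 to compound 3 (0.00 log units; within the scatter) is within the scatter; the pair rests only on (the fact that compounds 2 and 3 differ only in the configuration as drawn). Compound 1 gives 136000 nM, a clearly higher number.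

Compound 4 `CC(=O)OC[C@H]1O[C@@H](n2cc(CN3C(=O)/C(=C\c4ccc5ccccc5c4)c4ccccc43)nn2)[C@H](OC(C)=O)[C@@H](OC(C)=O)[C@@H]1OC(C)=O` differs from compound 3 by naphthalen-2-yl in place of 4-methylphenyl on a double-bonded chain carbon bound to a double-bonded ring carbon. Among the measured compounds shown here, no measured step touches this aryl position; the one measured step, from compound 2 to compound 3, concerns geometry alone and is within the scatter. For compound 4 in this assay the estimate is therefore 7500 nM, with a range of 2500 nM to 25000 nM. That estimate corresponds to an expected step of a 1.3-fold lower number from compound 3 to compound 4 (0.10 log units; within the scatter), essentially no change beyond the scatter.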

Compound 4, half-maximal inhibitory concentration: > 100000 nM
Compound 4: only a limit was reported; the forecaster's own chance of this, stated with the estimate: 5%; middle value at least 13-fold (1.12 log units) from the limit.
By their numbers in this assay, from the lowest: compounds 2 and 3 (each within the scatter of the next); then compound 1.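

In this assay compound 4 gives > 100000 nM, a limit of the assay and not a number. Naphthalen-2-yl in place of 4-methylphenyl gives an at least 10-fold higher number from compound 3 to compound 4 (1.02 log units; beyond the scatter), so the aryl group on the double-bonded chain carbon bound to a double-bonded ring carbon matters to this read-out. The earlier pair varied only the drawn geometry of that double bond, and its step stayed within the scatter.

Still open, from the compounds shown here alone, is whether a smaller group here, such as unsubstituted phenyl, or a 4-methoxyphenyl would hold the activity of compound 3. Also open, going by these compounds, is whether the drawn geometry stays without consequence with naphthalen-2-yl in place.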